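Benzylsulfanyl variation on a weakly cytotoxic oxadiazole series

The source may report more compounds than this note shows. Statements on the series, on what has been measured and on what is new or still open speak of the compounds shown alone.

Measured compounds:
compound 2 `Cn1nc(-c2nnc(SCc3c(F)cccc3F)o2)cc1-c1ccc(C(F)(F)F)cc1`, 38000 nM
compound 3 `Cn1nc(-c2nnc(SCc3cccc(Cl)c3Cl)o2)cc1-c1ccc(C(F)(F)F)cc1`, 54300 nM
compound 1 `Cn1nc(-c2nnc(S)o2)cc1-c1ccc(C(F)(F)F)cc1`, "not determined" (no result reported)

In a functional assay on A549 cells (Homo sapiens) for cytotoxicity, read by MTT assay, with a stated time of 24 h (on this read-out lower numbers stand for stronger inhibition and higher numbers for weaker inhibition), compound 2 gives 38000 nM, the lower of the two numbers, while compound 3 gives 54300 nM; for compound 1 no result is reported. Among the measured compounds shown here, the only step, a 1.4-fold higher number from compound 2 to compound 3 (0.16 log units; within the scatter), stays within the scatter. Compound 4 `Cn1nc(-c2nnc(SCc3ccc(Cl)cc3F)o2)cc1-c1ccc(C(F)(F)F)cc1` differs from compound 2 by 4-chloro-2-fluorophenyl in place of 2,6-difluorophenyl on a saturated chain carbon bound to a sulfur. This resembles the step from compound 2 to compound 3, which was also a swap of one halogenated benzyl group for another and gave no change beyond the scatter, so compound 4 is expected to show a 1.2-fold higher number from compound 2 to compound 4 (0.07 log units; within the scatter), no shift beyond the scatter. The estimate for compound 4 in this assay is 45000 nM, within 20000 nM to 100000 nM.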

Compound 4, half-maximal inhibitory concentration: 48200 nM
Compound 4: middle estimate off by 1.1-fold (0.03 log units), on the low side, within the range that was stated.
By their numbers in this assay, from the lowest: compounds 2, 4 and 3 (each within the scatter of the next).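

In this assay the 4-chloro-2-fluorophenyl group on a saturated chain carbon bound to a sulfur gives a 1.3-fold higher number from compound 2 to compound 4 (0.10 log units; within the scatter) and a 1.1-fold lower number from compound 3 to compound 4 (0.05 log units; within the scatter) and so adds a third halogenated phenyl group that cannot be told apart from the other two. Among compounds 2, 3 and 4, changing the halogens and their printed positions on the phenyl group therefore separates nothing, and no compound goes against this. No measured evidence bears on this flat result.

Going by these compounds, whether an amine or a carboxylic acid on the phenyl group, or a longer chain in place of the benzyl link, would move the number beyond the scatter stays open.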